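The source may hold more compounds than are shown below. What is called first, only, known or untested is meant among the compounds shown, and "the series" means these compounds.

The series shares one core, and compound 1 `CNC[C@@H]1CCC[C@H]1c1ccc2[nH]cc(C#N)c2c1` shows what it can do: in an assay on HEK293 cells for displacement of a labelled ligand from sodium-dependent dopamine transporter (Homo sapiens) (a lower number here means a stronger inhibitor, a higher number a weaker inhibitor), compound 1 gives 750 nM. Compound 2 `CN(C)C[C@H]1CCC[C@H]1c1ccc2[nH]cc(C#N)c2c1` carries a dimethylamino group at the chain end and the other arrangement at the ring carbon that bears that chain; in this assay compound 2 gives "not determined" (no result reported), so the record gives no number for compound 2 to stand on. Compound 3 `CNC[C@H]1CCC[C@H]1c1ccc2[nH]cc(C#N)c2c1` differs from compound 2 in one respect, (hydrogen in place of methyl on an amine nitrogen), that is, hydrogen in place of methyl on an amine nitrogen, leaving a methylamino group in place of the dimethylamino one. Among the measured compounds shown here, with no measured pair showing this exchange in this assay, the size of the step cannot be read from the data, and it could lie in either direction, or within the usual scatter. Compound 3 is at the same time a stereoisomer of compound 1, which is the only anchor. Since compound 1 gives 750 nM, compound 3 is expected to come out near 1000 nM, with a range from 200 nM to 5000 nM.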

Compound 3, half-maximal inhibitory concentration: 660 nM
Compound 3: the middle estimate sits 1.5-fold (0.18 log units) above what was measured; the measured number falls inside the stated range.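

In this assay, among the compounds shown here, the first step that can be read is a change of configuration, and it amounts to a 1.1-fold lower number from compound 1 to compound 3 (0.06 log units; within the scatter). With a methylamino group at the chain end, drawing the saturated ring carbon as R or as S therefore leaves the number within the scatter, so at this stereocentre the assay separates neither arrangement from the other. The comparison isolates that single stereocentre, with nothing else in the structures to account for: the fact that compounds 1 and 3 differ only in the configuration as drawn.

Compound 2 has no number and its step to compound 3 cannot be read, which leaves open the size and direction of the exchange of methyl for hydrogen on the amine nitrogen, and also whether the configuration at this ring carbon would matter as little with a dimethylamino group at the chain end. Also open, going by these compounds, are what a primary amine or an ethylamino group at the chain end, or a longer chain between the saturated ring and the amine, would do to the number, and what a change at the second stereocentre would do.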